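Swapping 4-methylpiperazin-1-yl for 3-oxomorpholin-4-yl: working notes

The source may report more compounds than this note shows. Statements on the series, on what has been measured and on what is new or still open speak of the compounds shown alone.

Measured so far (a physicochemical assay for lipophilicity; a lower number here means a more polar compound, a higher number a more lipophilic compound):
- compound 1 `CN1CCN(c2cc(C(F)(F)F)ccc2[C@H]2CCOc3cc(S(=O)(=O)Nc4nccs4)ccc32)CC1` gives 2.1 as its value
- compound 2 `O=S(=O)(Nc1nccs1)c1ccc2c(c1)OCC[C@H]2c1ccc(C(F)(F)F)cc1-c1ccc(F)nc1` gives "not determined" (no result reported) as its result

Among the compounds with values here, compound 1 carries the only number, so it has no rank yet, and compound 2 offers no comparison. Compound 3 `O=C1COCCN1c1cc(C(F)(F)F)ccc1[C@H]1CCOc2cc(S(=O)(=O)Nc3nccs3)ccc21` is still unmeasured and differs from compound 1 in one place, on an aromatic carbon: 3-oxomorpholin-4-yl in place of 4-methylpiperazin-1-yl (3-oxomorpholin-4-yl in place of 4-methylpiperazin-1-yl on an aromatic carbon). Within the data shown here, no measured pair shows what such an exchange does, so the expectation rests on the structural change alone and remains loose. A modest upward step is expected (a number 0.40 log units higher from compound 1 to compound 3 (beyond the scatter)) in this assay rather than a large one. Compound 3 is estimated at 2.5 (expected range 1.8 to 3.2) with even the direction uncertain.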

Compound 3, distribution coefficient: 1.8
The estimate for compound 3 lay 0.70 log units above the measured number; low and high end bracket the measured number.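

In this assay, within the data shown here, the single measured exchange on this aromatic carbon, ortho to a large group and meta to a trifluoromethyl group, gives a number 0.30 log units lower from compound 1 to compound 3 (within the scatter). At this place, therefore, 3-oxomorpholin-4-yl and 4-methylpiperazin-1-yl cannot be told apart in this read-out, although the entering group brings oxygen in place of a carbon and a nitrogen and adds a carbonyl, while the ring size and heavy-atom count stay the same. No accompanying measurement speaks to the reason for this result.

As far as these compounds go, it remains open whether a carboxylic acid, a primary amine or an open chain such as 2-methoxyethyl on the same carbon would give a step beyond the scatter. From the compounds shown here alone, it is also open whether this exchange would give a similar step with any change to the shared core.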